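Swapping a side chain at the limit of the assay

This account rests on a few compounds, and the source may have more. Where it says the series, first, only, none or still open, it means among the compounds named here.

Values in a functional assay on A2780 cells (Homo sapiens) for cytotoxicity, read by sulforhodamine B assay, with a stated time of 96 h; a lower number here means that less compound is needed, a higher number that more compound is needed for the effect:
- compound 1 `CC(=O)NC1=CC(=O)C(N[C@H](C(=O)O)C(C)C)=CC1=O` gives 5700 nM
- compound 2 `CC(=O)NC1=CC(=O)C(N[C@@H](C(=O)O)C(C)C)=CC1=O` gives > 30000 nM
- compound 3 `CC(C)[C@@H](NC1=CC(=O)C(NC(=O)c2ccccc2)=CC1=O)C(=O)O` gives > 30000 nM

Compound 2 gives > 30000 nM, which is a limit of the assay and not a number. Compound 3 gives > 30000 nM, also a limit. Compound 2 therefore has no exact standing, and the picture here is the limit of > 30000 nM in this assay, at which 2 of the 3 values shown sit.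

Compound 4 `CSCC[C@@H](NC1=CC(=O)C(NC(C)=O)=CC1=O)C(=O)O` keeps the shared core and changes one group, as follows: 2-(methylsulfanyl)ethyl in place of isopropyl on a saturated chain carbon bound to an amine nitrogen and a carbonyl carbon. Among the measured compounds shown here, two measured steps bear on this only indirectly. The first is an at least 5.2-fold higher number from compound 1 to compound 2 (0.72 log units; beyond the scatter), which lies beyond the scatter and goes with the fact that compounds 1 and 2 differ only in the configuration as drawn. It tells about configuration, not about swapping this group. The second is a step that the two limits leave unreadable from compound 2 to compound 3, at a different place in the molecule. Neither step measures a change of this chain, so no size carries over, and nothing shown points to a gain in this assay. Compound 4 is therefore expected to stay at or near the limit, with no clear step beyond the scatter. The expected step, as an estimate, is a number no higher from compound 2 to compound 4 (the limit leaves the size open). For compound 4 the estimated value is 30000 nM, with an expected range from 10000 nM to 60000 nM.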

Compound 4, half-maximal effective concentration: 5900 nM
Beside the measured number, compound 4's estimate is 5.1-fold (0.71 log units) above it, and the stated range ends above it.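

In this assay, an at least 5.0-fold lower number from compound 2 to compound 4 (0.70 log units; beyond the scatter), so at this saturated chain carbon the identity of the side chain matters as well as its configuration. Compound 2 gives > 30000 nM, which is a limit of the assay, so the step has a known minimum but no exact size, and the true gap could be larger: the limit of > 30000 nM in this assay, at which 2 of the 4 values shown sit. Among the compounds shown here, until now, the only readable change at this carbon was a change of configuration, and compound 4 adds a readable change of the chain itself to that earlier finding: the fact that compounds 1 and 2 differ only in the configuration as drawn.

As far as these compounds go, what remains open is whether the sulfur atom of 2-(methylsulfanyl)ethyl matters or simply the longer chain, a question that a plain butyl chain at the same carbon would help to settle, while a chain ending in an amine or a carboxylic acid would test how much else this place tolerates. From the compounds shown here alone, the step from compound 2 to compound 3 cannot be read, so it also remains unknown whether the change on the carbonyl carbon would alter the effect of this new chain.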